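This account rests on a few compounds, and the source may have more. Where it says the series, first, only, none or still open, it means among the compounds named here.

Compound 1, `CC[C@H](C)[C@H](NC(=O)c1cccc(Cn2ccnc2)c1)C(=O)NS(=O)(=O)c1ccccc1`, gives 5% in an assay on HEK293 cells for displacement of a labelled ligand from Type-2 angiotensin II receptor (Homo sapiens), tested at 1 uM; on this read-out higher numbers stand for a stronger effect at the one concentration tested and lower numbers for a weaker effect.
Compound 2, `CC[C@H](C)[C@H](NC(=O)c1cccc(Cn2ccnc2)c1)C(=O)NNC(=O)OC(C)(C)C`, gives "not determined" (no result reported) in this assay.
Compound 3, `CC[C@H](C)[C@H](NC(=O)c1cccc(Cn2ccnc2)c1)C(N)=O`, gives "not active" (no number reported) in this assay.

All three compounds share the same core and differ in a single group. Compound 3 carries a carbamoyl group, and in this assay it has no single number: the result for compound 3 was reported as not active, so it cannot be ranked against any other compound. Compound 2 also has no number. Only compound 1 gives a figure, and that figure is small.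

Compound 4 is `CC[C@H](C)[C@H](NC(=O)c1cccc(Cn2ccnc2)c1)C(=O)NC#N`. It differs from compound 3 in one place: cyano in place of hydrogen on an amide-type nitrogen. Among the measured compounds shown here, no step between two measured compounds is available, so the size of this change can only be estimated. Given that compound 3 was reported as "not active" (no number reported) and compound 1 gives 5% in this assay, no step beyond the usual scatter is expected for compound 4, only a possible small rise that keeps it at the low end of the read-out. Compound 4 is therefore expected to give about 8% in this assay, within a range from 0% to 25%.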

Compound 4, a percentage reported as inhibition, at one concentration (the size of the read-out at that concentration, not a potency): 6%
For compound 4 the middle estimate is 2 percentage points above the measured one, and the stated range covers the measured number.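

In this assay, among the compounds shown here, putting cyano in place of phenylsulfonyl on the amide-type nitrogen gives a number 1 percentage points higher from compound 1 to compound 4 (within the scatter), so this is the first pair at this position that can be compared by number. A group with no ring and a group that carries a phenyl ring read alike here, and this pair gives no sign that the read-out at the one tested concentration depends on which of the two sits on this nitrogen. Steps involving compound 2 or compound 3 cannot be read, and nothing among the data given accounts for the likeness of the two numbers.

What the compounds shown leave open is whether any group on this nitrogen can lift the read-out clearly beyond the usual scatter, since only two groups can be compared by number so far. A methyl group, an acetyl group or a longer alkyl chain on this nitrogen, or a carboxylic acid in place of the whole carbamoyl group, would test whether this position can change the result at all.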